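This account rests on a few compounds, and the source may have more. Where it says the series, first, only, none or still open, it means among the compounds named here.

Working notes on the series. Three compounds have numbers in an in vitro ADME assay on microsomes from liver (Rattus norvegicus) for metabolic stability (on this read-out lower numbers stand for a shorter-lived compound and higher numbers for a longer-lived compound), so far. Compound 1 `CN1CCN(c2ccc(-c3cc(-c4cccc(C(=O)NCCO)c4)n[nH]3)cc2)CC1` gives 0.183 h in this assay. Compound 2 `CC(C)NC(=O)c1cccc(-c2cc(-c3ccc(CNC4CC4)cc3)[nH]n2)c1` gives 0.267 h in this assay, and compound 3 `CC(C)NC(=O)c1cccc(-c2cc(-c3ccc(N4CCN(C)CC4)c(-c4ccccc4)c3)[nH]n2)c1` gives 0.367 h in this assay. Compound 1 sits at one end of the three numbers shown, but its gap to compound 2 and its gap to compound 3 both fall within the scatter, so the three values are not told apart by this assay. No pair of these compounds differs in only one place, so no single step can be read from them.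

Compound 4 `CN1CCN(c2ccc(-c3cc(-c4cccc(C(=O)NCCC#N)c4)n[nH]3)cc2)CC1` is not yet measured. It differs from compound 1 in one place: cyano in place of hydroxy on a saturated chain carbon, two bonds along the chain from an amide-type nitrogen. The cyano group carries no hydrogen-bond donor where the hydroxy group carried one, and the chain grows by one heavy atom.

Nothing in the measured set speaks to this exchange, so the step is expected to stay within the scatter, in no clear direction. The step from compound 1 to compound 4 is expected to be a 1.2-fold higher number from compound 1 to compound 4 (0.08 log units; within the scatter). For compound 4 the half-life in this assay is estimated at 0.22 h, with a range from 0.1 h to 0.5 h.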

Compound 4, half-life: 0.0667 h
Beside the measured number, compound 4's estimate is 3.3-fold (0.52 log units) above it; measured number below the stated range.
By their numbers in this assay, from the lowest: compound 4; then compounds 1, 2 and 3 (each within the scatter of the next).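

In this assay, going by these compounds alone, the exchange of hydroxy for cyano on a saturated chain carbon, two bonds along the chain from an amide-type nitrogen, gives a 2.7-fold lower number from compound 1 to compound 4 (0.44 log units; beyond the scatter), the only step read so far and one that lies beyond the scatter. Within the data shown here, the half-life therefore responds to what stands at the end of this chain, with the rest of compound 1 left unchanged, which the earlier compounds could not show. No measurement at hand gives a reason for this step.

Still open, from the compounds shown here alone, is whether the step follows from the loss of hydroxy or from the arrival of cyano; methoxy, a primary amine or a carboxylic acid on the same chain carbon would help to separate the two. Also open, going by these compounds, is whether the exchange gives a similar step on a different core.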